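Chloro in Place of Hydrogen on Two Different Cores

The compounds below may be only part of what the source reports. "The series", "measured", "known", "first", "only" and "open" are said of these compounds alone.

Measured so far:
compound 1 `NC1=NC2(CCCCC2)N(c2ccccc2)C(N)=N1`, > 100000 nM
compound 2 `NC1=NC2(CCCCC2)N(c2ccccc2Cl)C(N)=N1`, > 100000 nM
compound 3 `CC1(C)N=C(N)N=C(N)N1Cc1ccccc1`, 19500 nM

All three were tested in an assay for inhibition of Dihydrofolate reductase (Bos taurus), using NADPH; on this read-out higher numbers stand for weaker inhibition and lower numbers for stronger inhibition. In this assay compound 1 gives > 100000 nM, which is a limit of the assay and not a number. Compound 2 likewise gives > 100000 nM, also a limit. For the measured compounds named here, compound 3 gives 19500 nM, the only number among the three. Compound 2 differs from compound 1 by chloro in place of hydrogen on an aromatic carbon; the step is a step that the two limits leave unreadable from compound 1 to compound 2, and its size cannot be read because both values sit at the limit of > 100000 nM in this assay, at which 2 of the 3 values shown sit. How the core of compound 3 differs from that of compound 1 is not broken down here.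

Compound 4 `CC1(C)N=C(N)N=C(N)N1Cc1ccc(Cl)cc1` has not yet been measured. It differs from compound 3 by chloro in place of hydrogen on an aromatic carbon. This is the same kind of change as that from compound 1 to compound 2, though here the chloro sits para to a large group, whereas in compound 2 it sits ortho to a large group. The measured step gives no size to lean on, so the expectation for compound 4 rests on compound 3 giving 19500 nM alone. The step expected from compound 3 to compound 4 is estimated at a 1.6-fold lower number from compound 3 to compound 4 (0.21 log units; within the scatter). Compound 4 is therefore expected to give about 12000 nM, with a likely range from 4000 nM to 40000 nM.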

Compound 4, half-maximal inhibitory concentration: 29900 nM
Compound 4: middle estimate off by 2.5-fold (0.40 log units), on the low side, and the stated range covers the measured number.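

In this assay, chloro in place of hydrogen on an aromatic carbon of compound 3 gives a 1.5-fold higher number from compound 3 to compound 4 (0.19 log units; within the scatter), so on this core the change has no effect that can be told apart from the usual scatter. For the compounds shown here, the same kind of change on the core of compound 1 cannot be read, since compound 1 and compound 2 both sit at a limit of the assay and not at a number: the limit of > 100000 nM in this assay, at which 2 of the 4 values shown sit. This leaves only one readable step, so the account shows neither that the change carries from one core to the other nor that it fails to, and the chloro of compound 4, para to a large group, does not share its place with that of compound 2.

As far as these compounds go, it remains open whether chloro elsewhere on the six-membered aromatic ring of compound 3 would give a step beyond the scatter. From the compounds shown here alone, it is equally open whether a different group in the place of this chloro, such as an amine or a carboxylic acid, would do so.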